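Compound 3 to compound 4: one more carbon on the side chain

A few compounds are considered here, and "the series" means these few. Any claim that something is new, unique, unknown or untested is made for them only; others in the source may bear on it.

Compound 1 `COc1cc2cc(C#N)ccc2c(OC)c1Oc1cc(NCC(C)(C)C)nc(Nc2ccc(C#N)cc2)n1`, compound 2 `COc1cc2cc(C#N)ccc2c(OC)c1Oc1cc(NC2CCOCC2)nc(Nc2ccc(C#N)cc2)n1` and compound 3 `COc1cc2cc(C#N)ccc2c(OC)c1Oc1cc(NC2CCOC2)nc(Nc2ccc(C#N)cc2)n1` share a core. In an ADME assay on MT4 cells (Homo sapiens) for cytotoxicity, read by MTT assay, with a stated time of 5 days (on this read-out lower numbers stand for higher toxicity in this test and higher numbers for lower toxicity in this test), compound 1 gives > 125000 nM, a limit. Compound 2 gives > 125000 nM, also a limit. Compound 3 gives > 125000 nM, again a limit, so it has no number of its own. The series stands at the limit of > 125000 nM in this assay, at which 3 of the 3 values shown sit.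

Compound 4 `COc1cc2cc(C#N)ccc2c(OC)c1Oc1cc(NCC2CCOC2)nc(Nc2ccc(C#N)cc2)n1` carries (oxolan-3-yl)methyl in place of oxolan-3-yl on a nitrogen on an aromatic ring. The nearest measured changes are a step that the two limits leave unreadable from compound 2 to compound 3 and a step that the two limits leave unreadable from compound 1 to compound 3, and neither has a readable size. No value has yet left the limit, so no shift is expected in this assay. The expected move is a number no higher from compound 3 to compound 4 (the limit leaves the size open), within the scatter. Compound 4 is estimated at 125000 nM, with a range of 50000 nM to 200000 nM.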

Compound 4, half-maximal cytotoxic concentration: > 125000 nM
Compound 4 gave a limit, no number; the forecaster's own chance of this, stated with the estimate: 85%; the middle value lies on the limit itself.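

In this assay compound 4 gives > 125000 nM, a limit. Its steps from compound 1, compound 2 and compound 3 cannot be read. Still open is whether any side chain on the shared core gives a number of its own in this assay: the limit of > 125000 nM in this assay, at which 4 of the 4 values shown sit.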